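Ethoxy to Methyl on the Aromatic Ring

The source may report more compounds than this note shows. Statements on the series, on what has been measured and on what is new or still open speak of the compounds shown alone.

Compound 1 `O=C1C=C(NCc2ccccc2)C(=O)c2c1nc1n2[C@H]2OC[C@@H](O)[C@H]2OC1` gives > 8000 nM (a limit of the assay)
Compound 2 `CCOc1ccc(NC2=CC(=O)c3nc4n(c3C2=O)[C@H]2OC[C@@H](O)[C@H]2OC4)cc1` gives 3210 nM

Among the measured compounds shown here, in a functional assay on ECa-109 cells for inhibition, with ECa-109 cell line (Homo sapiens) as the target, read by sulforhodamine B assay (a lower number here means a stronger inhibitor, a higher number a weaker inhibitor), compound 2 gives 3210 nM as the only true number so far. Compound 1 gives > 8000 nM in this assay as a limit of the assay and not a number.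

Compound 3 `Cc1ccc(NC2=CC(=O)c3nc4n(c3C2=O)[C@H]2OC[C@@H](O)[C@H]2OC4)cc1` carries methyl in place of ethoxy on an aromatic carbon, para to a large group, and the change in full is methyl in place of ethoxy on an aromatic carbon at that one place. For the measured compounds named here, the one measured step, an at least 2.4-fold lower number from compound 1 to compound 2 (0.39 log units; beyond the scatter) with 4-ethoxyphenyl in place of benzyl on an amine nitrogen, bears only loosely on this change: it replaced the whole group on the nitrogen, and no measured pair varies the ethoxy alone. On that thin footing no direction is favoured, and the estimated change is a 1.1-fold higher number from compound 2 to compound 3 (0.04 log units; within the scatter) in this assay with nothing beyond the scatter expected. Compound 3 is expected at an estimated 3500 nM with a range from 1300 nM to 8000 nM in this assay while its measurement stands open.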

Compound 3, half-maximal inhibitory concentration: 3480 nM
Compound 3: middle estimate off by 1.0-fold (0.00 log units), on the high side, and the stated range covers the measured number.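

Methyl in place of ethoxy on an aromatic carbon, para to a large group, gives a 1.1-fold higher number from compound 2 to compound 3 (0.04 log units; within the scatter) in this assay; this is the first pair that varies this one place alone, and it shows that the two groups cannot be told apart here. The gain over benzyl on the amine nitrogen also holds with 4-methylphenyl, at an at least 2.2-fold lower number from compound 1 to compound 3 (0.36 log units; beyond the scatter), so it does not depend on the ethoxy group. Compound 1 gives a limit of the assay and not a number, which leaves the true size of that step unknown: the limit of > 8000 nM in this assay, at which 1 of the 3 values shown sits.

The compounds shown leave open whether any group on this aromatic carbon can move the number beyond the scatter, since only ethoxy and methyl are seen there, and an amine or a carboxylic acid in that place would test this more widely. As far as these compounds go, it also remains open how a longer chain in place of the benzyl on the amine nitrogen would compare with 4-ethoxyphenyl and 4-methylphenyl.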